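The source may report more compounds than this note shows. Statements on the series, on what has been measured and on what is new or still open speak of the compounds shown alone.

Of the compounds shown here, three have been measured in a functional assay on A549 cells (Homo sapiens) for inhibition, read by MTT assay, with a stated time of 72 h, tested at 10 uM; a lower number here means less inhibition, a higher number more inhibition at the concentration tested (going by the name of the read-out).
Compound 1, `CCOC(=O)C1=C(Nc2ccccc2)S/C(=C\c2ccc(Br)c(O)c2)C1=O`, gives 13.6%.
Compound 2, `CCOC(=O)C1=C(Nc2ccccc2)S/C(=C\c2ccc(C(=O)O)cc2)C1=O`, gives 11.6%.
Compound 3, `CCOC(=O)C1=C(Nc2ccc(F)cc2)S/C(=C\c2ccc[nH]2)C1=O`, reaches only a limit of the measurement, < 10%, and not a number.

Within the data shown here, the one step between measured compounds that differ in a single place is a number 2 percentage points lower from compound 1 to compound 2 (within the scatter), with 4-carboxyphenyl in place of 4-bromo-3-hydroxyphenyl on a double-bonded chain carbon bound to a double-bonded ring carbon. Compound 3 is placed differently: its reading is one of those that sit at the limit (the limit of < 10% in this assay, at which 1 of the 3 values shown sits), so no number is known for it.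

Compound 4, `CCOC(=O)C1=C(Nc2ccc(CC)cc2)S/C(=C\c2ccc[nH]2)C1=O`, is the next compound to be measured. It differs from compound 3 in ethyl in place of fluoro on an aromatic carbon. Among the measured compounds shown here, no measured step touches this part of the molecule: the step from compound 1 to compound 2 changed the ring on the chain carbon, not the ring that carries the fluoro in compound 3, and even that change stayed within the scatter. For the measured compounds named here, with compound 3 at the limit and no step reaching beyond the scatter, compound 4 is expected to stay near the bottom of the scale, with an expected change of a step that the limit leaves unreadable from compound 3 to compound 4 in this assay. The estimate for compound 4 in this assay is 8%, within a range from 0% to 20%, and a limit rather than a number may well be reported again.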

Compound 4, a percentage reported as inhibition, at one concentration (the size of the read-out at that concentration, not a potency): 17.5%
The estimate for compound 4 lay 9.5 percentage points below the measured number, and the stated range covers the measured number.
By their numbers in this assay, from the lowest: compounds 2, 1 and 4 (each within the scatter of the next). At a limit, below all of these: compound 3.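

Among these compounds, this result gives the first reading on the six-membered aromatic ring that carries the fluoro in compound 3, since the earlier step changed only the ring on the chain carbon. In this assay, putting ethyl in place of fluoro para to a large group gives a number at least 7.5 percentage points higher from compound 3 to compound 4 (that floor lies within the scatter), and compound 4 gives 17.5%, a number rather than a limit, so this position now has one reading that can be compared directly with later changes. Even so, the size of the step cannot be fixed, and whether it exceeds the scatter stays unknown because one end of it is only a limit: the limit of < 10% in this assay, at which 1 of the 4 values shown sits.

The compounds shown leave open whether a longer chain such as butyl, or an amine or a carboxylic acid, at this same place would give a reading clearly beyond the scatter. They also leave open whether ethyl at this place would do the same in a compound carrying the 4-bromo-3-hydroxyphenyl or 4-carboxyphenyl group of compound 1 or compound 2 on the chain carbon.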